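Working notes: ethoxycarbonyl in place of hydroxymethyl on compound 2

The compounds below may be only part of what the source reports. "The series", "measured", "known", "first", "only" and "open" are said of these compounds alone.

Measured in a functional assay on QGY cells (Homo sapiens) for cytotoxicity, read by MTT assay, with a stated time of 48 h; a lower number here means a stronger inhibitor, a higher number a weaker inhibitor
- compound 1 `CCOC(=O)[C@]1(C(=O)Nc2ccccc2)C[C@@H]1c1cc(OC)c(OC)c(OC)c1` gives 38100 nM
- compound 2 `COc1cc([C@H]2C[C@]2(CO)C(=O)Nc2ccccc2Cl)cc(OC)c1OC` gives 40700 nM

Compound 2 stands within the scatter of compound 1, so these two numbers give no ranking. The next compound is compound 3 `CCOC(=O)[C@]1(C(=O)Nc2ccccc2Cl)C[C@@H]1c1cc(OC)c(OC)c(OC)c1`, where ethoxycarbonyl takes the place of hydroxymethyl on a saturated ring carbon, next to the ring atom that bears a large group: ethoxycarbonyl in place of hydroxymethyl on a saturated ring carbon. Among the compounds with values here, the series holds no measured pair that differs in one place, so this change has no direct precedent. Within the data shown here, the only guide is that compound 1 also carries ethoxycarbonyl and gives 38100 nM, a value within the scatter of the one for compound 2. On that basis, no step beyond the scatter is expected in this assay, in either direction, though this rests on very few data. The expected change is a 1.1-fold lower number from compound 2 to compound 3 (0.05 log units; within the scatter). The estimated value for compound 3 is 36000 nM, with an expected range from 16000 nM to 80000 nM.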

Compound 3, half-maximal inhibitory concentration: 34700 nM
Estimate against measurement, compound 3: 1.0-fold (0.02 log units) above; measured number inside the range.
By their numbers in this assay, from the lowest: compounds 3, 1 and 2 (each within the scatter of the next).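

In this assay, within the data shown here, ethoxycarbonyl in place of hydroxymethyl on a saturated ring carbon of the three-membered ring gives a 1.2-fold lower number from compound 2 to compound 3 (0.07 log units; within the scatter) and so provides the first direct reading at this position: exchanging a group that has a hydrogen-bond donor for a longer ester group that has none leaves no difference that can be separated from the scatter. Chloro in place of hydrogen on an aromatic carbon, with ethoxycarbonyl held constant, gives a 1.1-fold lower number from compound 1 to compound 3 (0.04 log units; within the scatter) and is likewise no readable difference, so neither single-place change among these three compounds sets one apart from another in this assay. No supporting measurement is available to account for these results.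

As far as these compounds go, whether any group on this saturated ring carbon can move the number beyond the scatter remains open, and a carboxylic acid or an aminomethyl group there would test this with groups unlike both hydroxymethyl and ethoxycarbonyl. The aromatic carbon is equally unresolved, since chloro is the only group shown there in place of hydrogen, and methoxy or nitrile would give a further reading.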